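This account rests on a few compounds, and the source may have more. Where it says the series, first, only, none or still open, it means among the compounds named here.

Compound 1 `COc1cc2c(Nc3ccc(C#N)cc3)ncnc2cc1OCCCN1CCC(CO)CC1`: 21600 nM
Compound 2 `COc1cc2c(Nc3ccc(C#N)cc3)ncnc2cc1OCCCN1CCC(N2CCCCC2)CC1`: 9810 nM

In a functional assay on SH-SY5Y cells (Homo sapiens) for antiproliferative activity, read by MTT assay, with a stated time of 72 h (on this read-out higher numbers stand for weaker inhibition and lower numbers for stronger inhibition), compound 1 stands at the highest of the two numbers. Within the data shown here, the one measured step, a 2.2-fold lower number from compound 1 to compound 2 (0.34 log units; beyond the scatter), shows that altering the group on the saturated ring of this tail moved the number only modestly. Compound 3 `COc1cc2c(Nc3ccc(C#N)cc3)ncnc2cc1OCCCN1CCN(C)CC1` differs from compound 1 in that same tail: 4-methylpiperazin-1-yl in place of 4-(hydroxymethyl)piperidin-1-yl on a saturated chain carbon, three bonds along the chain from an oxygen on an aromatic ring. The step of a 2.2-fold lower number from compound 1 to compound 2 (0.34 log units; beyond the scatter) bears on this change, and a step of similar, modest size toward a lower number is expected for compound 3 as well, a 1.5-fold lower number from compound 1 to compound 3 (0.19 log units; within the scatter). Compound 3 is therefore estimated at 14000 nM, with a likely range from 5500 nM to 35000 nM.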

Compound 3, half-maximal inhibitory concentration: 13000 nM
Estimate against measurement, compound 3: 1.1-fold (0.03 log units) above; measured number inside the range.
By their numbers in this assay, from the lowest: compounds 2, 3 and 1 (each within the scatter of the next, the first and the last beyond it).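

Exchanging 4-(hydroxymethyl)piperidin-1-yl for 4-methylpiperazin-1-yl removes the hydrogen-bond donor and adds a second ring hetero atom, yet in this assay the result stays within the scatter (a 1.7-fold lower number from compound 1 to compound 3 (0.22 log units; within the scatter)). The same holds when 4-methylpiperazin-1-yl is compared with the larger 4-(piperidin-1-yl)piperidin-1-yl (a 1.3-fold higher number from compound 2 to compound 3 (0.12 log units; within the scatter)), so compound 3 cannot be separated from either neighbour. No available evidence explains these results. Going by these compounds, it remains open whether a morpholin-4-yl group, a carboxylic acid or a chain longer than propyl would change the number beyond the scatter.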